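The source may report more compounds than this note shows. Statements on the series, on what has been measured and on what is new or still open speak of the compounds shown alone.

Measured in an ADME assay on Vero cells (Chlorocebus sabaeus) for cytotoxicity, with a stated time of 5 days (on this read-out higher numbers stand for weaker inhibition and lower numbers for stronger inhibition), so far:
Compound 1 `CC(C)(CO)Nc1nc(N)nc2c1ncn2[C@H]1C[C@H](N=[N+]=[N-])[C@@H](CO)O1` gives > 100000 nM as a limit.
Compound 2 `[N-]=[N+]=N[C@H]1C[C@H](n2cnc3c(NCCCCCO)nc(N)nc32)O[C@@H]1CO` gives > 100000 nM as a limit.
Compound 3 `CNc1nc(Cl)nc2c1ncn2[C@H]1C[C@H](N=[N+]=[N-])[C@@H](CO)O1` gives > 100000 nM as a limit.

Every reading so far is the limit of > 100000 nM in this assay, at which 3 of the 3 values shown sit, and none is a number. Compound 2 therefore stands at a limit, and the other two compounds offer only limits to set it against.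

In compound 4 `CC(CO)Nc1nc(N)nc2c1ncn2[C@H]1C[C@H](N=[N+]=[N-])[C@@H](CO)O1`, 1-(hydroxymethyl)ethyl stands in place of 5-hydroxypentyl on a nitrogen on an aromatic ring (1-(hydroxymethyl)ethyl in place of 5-hydroxypentyl on a nitrogen on an aromatic ring). Among the compounds with values here, the one measured step at this place is a step that the two limits leave unreadable from compound 1 to compound 2 and it gives no size to carry over. Compound 1, which carries 1-(hydroxymethyl)-1-methylethyl there, also sits at a limit (> 100000 nM). No step beyond the scatter is therefore expected in this assay and no direction can be assigned. The expected size is a number no higher from compound 2 to compound 4 (the limit leaves the size open) on this reasoning. The estimate for compound 4 is 100000 nM with an expected range from 30000 nM to 300000 nM and a report as a limit is the likeliest outcome.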

Compound 4, half-maximal inhibitory concentration: > 100000 nM
Compound 4: a limit, no number; the forecaster's own chance of this, stated with the estimate: 85%; the middle value lies on the limit itself.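

In this assay compound 4 gives > 100000 nM, a limit and not a number. Within the data shown here, no step from compound 1 or compound 2 to compound 4 can be read. The compounds shown leave open whether any of these side chains on the nitrogen changes the read-out at all.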